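This account rests on a few compounds, and the source may have more. Where it says the series, first, only, none or still open, it means among the compounds named here.

Of the compounds shown here, three built on one shared core have so far been measured in a functional assay on KBVIN cells (Homo sapiens) for antiproliferative activity, read by sulforhodamine B assay, with a stated time of 3 days; a lower number here means that less compound is needed, a higher number that more compound is needed for the effect. Compound 2 `CCC1=C(O)c2c(oc(-c3ccc(F)cc3)cc2=O)C(CC)(CC)C1=O` gives 1.85 uM, the lowest of the three numbers; compound 3 `CCC1=C(O)c2c(oc(-c3cccc(OC(F)(F)F)c3)cc2=O)C(CC)(CC)C1=O` gives 9.95 uM, and compound 1 `CCCOc1ccc(-c2cc(=O)c3c(o2)C(CC)(CC)C(=O)C(CC)=C3O)cc1` gives 29.2 uM. Compound 4 `CCC1=C(O)c2c(oc(-c3ccc(OC)cc3C)cc2=O)C(CC)(CC)C1=O` differs from compound 2 in a single place: 4-methoxy-2-methylphenyl in place of 4-fluorophenyl on an aromatic carbon. Going by the values given here, the only measured step that changes one place is a 16-fold lower number from compound 1 to compound 2 (1.20 log units; beyond the scatter), and the change to compound 4 looks like the reverse of that step, since an oxygen-bearing group again stands where the fluorine was, though a shorter one and with a methyl added. A higher number beyond the scatter is therefore expected, though smaller than the full measured step. Compound 4 is estimated to give 8 uM, within 2.5 uM to 25 uM, which amounts to a 4.3-fold higher number from compound 2 to compound 4 (0.64 log units; beyond the scatter).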

Compound 4, concentration for half-maximal effect: 2.62 uM
Beside the measured number, compound 4's estimate is 3.1-fold (0.48 log units) above it; measured number inside the range.
By their numbers in this assay, from the lowest: compounds 2 and 4 (each within the scatter of the next); then compound 3; then compound 1.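

In this assay, 4-methoxy-2-methylphenyl in place of 4-fluorophenyl gives a 1.4-fold higher number from compound 2 to compound 4 (0.15 log units; within the scatter), so this place tolerates the larger group, with its oxygen and added methyl, without a change beyond the scatter. An oxygen-bearing group here therefore does not by itself bring a step as large as a 16-fold lower number from compound 1 to compound 2 (1.20 log units; beyond the scatter). Nothing measured here explains this result. On these data alone, the methoxy and the methyl enter together, so what each contributes alone stays open. As far as these compounds go, how an amine or a carboxylic acid in this place would read also stays open.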